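A few compounds are considered here, and "the series" means these few. Any claim that something is new, unique, unknown or untested is made for them only; others in the source may bear on it.

Compound 3 `Cc1nc(S(C)(=O)=O)ccc1Oc1ncnc(OC2CCN(C(=O)OC3(C(F)(F)F)COC3)CC2)c1F` gives 29.3 nM in a functional assay on isolated protein for inhibition of Glucose-dependent insulinotropic receptor (Homo sapiens), read by HTRF and cAMP accumulation (a lower number here means that less compound is needed, a higher number that more compound is needed for the effect), the second highest of the three numbers seen so far. Compound 1 `Cc1nc(S(C)(=O)=O)ccc1Oc1ncnc(OC2CCN(C(=O)OC(C)C)CC2)c1F` gives 21 nM in this assay, and the step of a 1.4-fold higher number from compound 1 to compound 3 (0.14 log units; within the scatter) lies within the scatter. Compound 2 `Cc1nc(S(C)(=O)=O)ccc1Oc1ncnc(OC2CCN(C(=O)O[C@@H](C)CF)CC2)c1F` gives 186 nM in this assay; the step of a 6.3-fold lower number from compound 2 to compound 3 (0.80 log units; beyond the scatter) lies beyond the scatter, as does the step of an 8.9-fold higher number from compound 1 to compound 2 (0.95 log units; beyond the scatter). Compound 4 `Cc1nc(S(C)(=O)=O)ccc1Oc1ncnc(OC2CCN(C(=O)C(C)(F)F)CC2)c1F` differs from compound 3 by 1,1-difluoroethyl in place of (3-(trifluoromethyl)oxetan-3-yl)oxy on a carbonyl carbon. Going by the values given here, none of the measured steps bears directly on this change: each of them only exchanges the group on an oxygen next to a carbonyl group, and those exchanges ranged from within the scatter to modest. Compound 4 is thus expected to show only a small rise, a 2.0-fold higher number from compound 3 to compound 4 (0.31 log units; beyond the scatter), with wide uncertainty. The estimate for compound 4 in this assay is 60 nM, in a range from 15 nM to 250 nM.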

Compound 4, half-maximal effective concentration: 37 nM
For compound 4 the middle estimate is 1.6-fold (0.21 log units) above the measured one, within the range that was stated.
By their numbers in this assay, from the lowest: compounds 1, 3 and 4 (each within the scatter of the next); then compound 2.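

In this assay the group on the carbonyl carbon need not be joined through oxygen: with 1,1-difluoroethyl there, the change gives a 1.3-fold higher number from compound 3 to compound 4 (0.10 log units; within the scatter) and, against isopropoxy, a 1.8-fold higher number from compound 1 to compound 4 (0.25 log units; within the scatter), both within the scatter. The 1-(fluoromethyl)ethyl group on oxygen stays apart, with a 5.0-fold lower number from compound 2 to compound 4 (0.70 log units; beyond the scatter). Nothing available explains why these groups read alike. The compounds shown leave open how a plain ethyl or a cyclopropyl group on this carbonyl carbon would read. They also leave open whether a dimethylamino group would fit there.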